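Geometric isomer of a thiazolidinone-oxindole pair in resistant leukemia cells

This account rests on a few compounds, and the source may have more. Where it says the series, first, only, none or still open, it means among the compounds named here.

Measured so far:
compound 1 `CN(C)CCn1c(=O)/c(=C/c2ccc(O)cc2)s/c1=C1/C(=O)Nc2ccc(F)cc21`: 6140 nM
compound 2 `CCN(CC)CCCn1c(=O)/c(=C/c2ccc(F)cc2F)s/c1=C1/C(=O)Nc2cc(F)ccc21`: 4120 nM

In a functional assay on K562/Adr cells (Homo sapiens) for cytotoxicity, read by sulforhodamine B assay, with a stated time of 48 h (a lower number here means a stronger inhibitor, a higher number a weaker inhibitor), compound 1 gives 6140 nM, the higher of the two numbers recorded, while compound 2 gives 4120 nM, a gap that lies within the scatter of repeated measurements, so neither can be called the stronger of the pair.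

Compound 3 `CN(C)CCn1c(=O)/c(=C/c2ccc(O)cc2)s/c1=C1\C(=O)Nc2ccc(F)cc21` has not yet been measured. Against compound 1 the change is the two compounds have the same atoms and bonds and differ only in configuration as drawn: 1 of 2 stereo elements differ; a double bond is drawn E in compound 1 and Z in compound 3. Within the data shown here, no measured pair in this set shows what such a change alone does to the read-out, so there is no step to lean on. The account therefore expects the step of a 1.0-fold lower number from compound 1 to compound 3 (0.01 log units; within the scatter) to fall within the scatter, with no direction favored. Compound 3 is accordingly estimated at 6000 nM, with a range from 2000 nM to 20000 nM to allow for the possibility that the drawn geometry matters more than the measured pair can reveal.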

Compound 3, half-maximal inhibitory concentration: 6140 nM
Compound 3: the middle estimate sits 1.0-fold (0.01 log units) below what was measured; measured number inside the range.
By their numbers in this assay, from the lowest: compounds 2, 1 and 3 (each within the scatter of the next).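

In this assay, among these compounds, the read-out shows no change at the digits printed from compound 1 to compound 3 (within the scatter), the first direct reading in this set of a change in drawn geometry alone. At this double bond, going from E as drawn to Z as drawn leaves the read-out unmoved, which compound 2 could not show, since it differs from compound 1 in more than one place. The pair isolates this single change, and the reason is this: the fact that compounds 1 and 3 differ only in the configuration as drawn

The compounds shown leave open whether the same holds for the geometry of compound 2, or for the other stereo element of compound 1, which stays the same in this pair. They also leave open whether a morpholine in place of the dimethylamino group, or a carboxylic acid in place of the hydroxy group, would move the read-out.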